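A few compounds are considered here, and "the series" means these few. Any claim that something is new, unique, unknown or untested is made for them only; others in the source may bear on it.

Among the compounds with values here, in a functional assay on HepG2 cells (Homo sapiens) for cytotoxicity, read by MTT assay, with a stated time of 48 h (on this read-out lower numbers stand for stronger inhibition and higher numbers for weaker inhibition), compound 1 `Cc1ccccc1-c1nnc(SCCn2c([N+](=O)[O-])cnc2C)o1` gives 5100 nM and compound 2 `Cc1ncc([N+](=O)[O-])n1CCSc1nnc(-c2ccccc2N)o1` gives 4500 nM, so compound 2 stands within the scatter of the only other measured number. Compound 3 `Cc1ncc([N+](=O)[O-])n1CCSc1nnc(-c2ccc(N)cc2)o1` is the next to read, with 4-aminophenyl in place of 2-aminophenyl on an aromatic carbon. Within the data shown here, the one measured step at this place, a 1.1-fold lower number from compound 1 to compound 2 (0.05 log units; within the scatter), lies within the scatter, but no measured step shifts the amino group. No change beyond the scatter is therefore expected in this assay. The expected step is a 1.1-fold lower number from compound 2 to compound 3 (0.03 log units; within the scatter). The estimate for compound 3 is 4200 nM, with an expected range of 1700 nM to 10000 nM.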

Compound 3, half-maximal inhibitory concentration: 6700 nM
The estimate for compound 3 lay 1.6-fold (0.20 log units) below the measured number, and the stated range covers the measured number.
By their numbers in this assay, from the lowest: compounds 2, 1 and 3 (each within the scatter of the next).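

In this assay, the amino group's position makes no difference beyond the scatter, with a 1.5-fold higher number from compound 2 to compound 3 (0.17 log units; within the scatter). Exchanging 2-methylphenyl for 4-aminophenyl also stays within the scatter, with a 1.3-fold higher number from compound 1 to compound 3 (0.12 log units; within the scatter), so all three aryl groups at this place on the shared core read alike. No available measurement bears on why these numbers stay so close.

Still open, going by these compounds, is how a carboxylic acid or a methoxy group in place of the amino group would read in this assay. These three compounds also leave open whether any change at this place can move the number beyond the scatter.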